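A few compounds are considered here, and "the series" means these few. Any claim that something is new, unique, unknown or untested is made for them only; others in the source may bear on it.

Series notes. Compound 1 `COc1cc(-c2nc3cc(/C=C4\SC(=O)N(CC(=O)N5CCCC5)C4=O)ccc3[nH]2)cc(OC)c1OC`, compound 2 `COc1cc(-c2nc3cc(/C=C4\SC(=O)N(Cc5ccccc5)C4=O)ccc3[nH]2)cc(OC)c1OC` and compound 3 `COc1cc(-c2nc3cc(/C=C4\SC(=O)N(Cc5cccc(C)c5)C4=O)ccc3[nH]2)cc(OC)c1OC` share one core and differ only in the group on a saturated chain carbon bound to an amide-type nitrogen in a ring. In a functional assay on HT-1080 cells (Homo sapiens) for inhibition, read by MTT assay, with a stated time of 48 h (a higher number here means a weaker inhibitor, a lower number a stronger inhibitor), compound 1 gives 2470 nM. In this assay compound 2 gives 660 nM, and compound 3 gives 4580 nM. Compound 3 has the highest of the three numbers: the gap to compound 1 is within the scatter a 1.9-fold higher number from compound 1 to compound 3 (0.27 log units; within the scatter), while the gap to compound 2 is beyond it a 6.9-fold higher number from compound 2 to compound 3 (0.84 log units; beyond the scatter). Among the compounds with values here, the step of a 3.7-fold lower number from compound 1 to compound 2 (0.57 log units; beyond the scatter) shows a plain phenyl at this place giving the lowest number so far.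

Compound 4 `COc1cc(CN2C(=O)S/C(=C\c3ccc4[nH]c(-c5cc(OC)c(OC)c(OC)c5)nc4c3)C2=O)cc(OC)c1OC` is not yet measured. It differs from compound 3 by 3,4,5-trimethoxyphenyl in place of 3-methylphenyl on a saturated chain carbon bound to an amide-type nitrogen in a ring. Within the data shown here, no measured step adds methoxy groups to this ring; the only change on an aromatic carbon at this place is a methyl, a 6.9-fold higher number from compound 2 to compound 3 (0.84 log units; beyond the scatter), which raised the number. Nothing measured tells how the 3,4,5-trimethoxyphenyl behaves here. The expectation for compound 4 in this assay is therefore a step of a 1.8-fold lower number from compound 3 to compound 4 (0.26 log units; within the scatter), not clearly beyond the scatter in either direction, with wide bounds. Compound 4 is estimated at 2500 nM, with a range from 600 nM to 10000 nM.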

Compound 4, half-maximal inhibitory concentration: 980 nM
Beside the measured number, compound 4's estimate is 2.6-fold (0.41 log units) above it, and the stated range covers the measured number.
By their numbers in this assay, from the lowest: compounds 2 and 4 (each within the scatter of the next); then compounds 1 and 3 (each within the scatter of the next).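

Working from this assay, a substituent on the phenyl at this position does not by itself raise the number: the change from 3-methylphenyl to 3,4,5-trimethoxyphenyl brings the number back down (step: a 4.7-fold lower number from compound 3 to compound 4 (0.67 log units; beyond the scatter)), and the trimethoxy ring sits with the plain phenyl (step: a 1.5-fold higher number from compound 2 to compound 4 (0.17 log units; within the scatter)). Compound 3 therefore stands against any general reading that substitution on this ring is penalised, and the earlier methyl step cannot be extended to other substituents. Within the data shown here, the 3,4,5-trimethoxyphenyl also keeps a separation from the (pyrrolidin-1-yl)carbonyl group (step: a 2.5-fold lower number from compound 1 to compound 4 (0.40 log units; beyond the scatter)), which shows that the plain phenyl is not the only aromatic group to do so, and no measurement at hand explains the difference between the two substituted rings.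

The compounds shown leave open whether all three methoxy groups are needed or whether a phenyl carrying a single methoxy group would stay level with compound 2 and compound 4. Also open, as far as these compounds go, is how this position would respond to an amine or a carboxylic acid on the ring, or to a longer chain between the ring and the amide-type nitrogen.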